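A few compounds are considered here, and "the series" means these few. Any claim that something is new, unique, unknown or untested is made for them only; others in the source may bear on it.

Of the compounds shown here, three of one series have been tested in an ADME assay on microsomes from liver (Mus musculus) for metabolic stability, read by LC-MS, with a stated time of 10 min, tested at 0.5 uM; on this read-out lower numbers stand for a less stable compound and higher numbers for a more stable compound. Compound 1 `c1ccc2c(c1)CN[C@H](CN(CCCN1CCNCC1)[C@H]1CCCc3cccnc31)C2` gives 88% in this assay. Compound 2 `c1ccc2c(c1)CN[C@@H](CN(CCCCN1CCNCC1)[C@H]1CCCc3cccnc31)C2` gives 96%, and compound 3 `c1ccc2c(c1)CN[C@@H](CN(CCC1CCNCC1)[C@H]1CCCc3cccnc31)C2` gives 32%. Compound 1 thus stands second highest of the three, within the scatter of compound 2 and far above compound 3. Going by the values given here, the only single-place step measured so far, a number 64 percentage points lower from compound 2 to compound 3 (beyond the scatter), shows how strongly the group on the chain can matter.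

Compound 4 `c1ccc2c(c1)CN[C@@H](CN(CCCN1CCNCC1)[C@H]1CCCc3cccnc31)C2` is the next compound to be measured. Compared with compound 1, (the two compounds have the same atoms and bonds and differ only in configuration as drawn: 1 of 2 stereo elements differ; a stereocentre at a saturated ring carbon is drawn S in compound 1 and R in compound 4). Among the compounds with values here, this is not a change of the chain or of any group, and no measured step covers a change of configuration alone; the step from compound 2 to compound 3 therefore does not bear on it. The two compounds whose values are within the scatter of each other, compound 1 and compound 2, also carry the two different configurations at this centre, which gives no sign of a large effect of the configuration. The expectation is that compound 4 behaves like compound 1 in this assay, with an expected step of no change at the digits printed from compound 1 to compound 4 (within the scatter). Compound 4 is therefore estimated at 88%, between 72% and 99%.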

Compound 4, percent of the compound remaining: 92%
Compound 4: the middle estimate sits 4 percentage points below what was measured; measured number inside the range.
By their numbers in this assay, from the lowest: compound 3; then compounds 1, 4 and 2 (each within the scatter of the next).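

In this assay, the stereocentre at a saturated ring carbon can now be judged on its own, and a number 4 percentage points higher from compound 1 to compound 4 (within the scatter) shows no measurable effect of drawing it R rather than S; this comparison is a clean one because nothing else changes: the fact that compounds 1 and 4 differ only in the configuration as drawn

The chain can also be read more closely, since a number 4 percentage points lower from compound 2 to compound 4 (within the scatter), so piperazin-1-yl in place of (piperazin-1-yl)methyl leaves the number within the usual scatter. In contrast, a number 60 percentage points higher from compound 3 to compound 4 (beyond the scatter), with (piperazin-1-yl)methyl in place of piperidin-4-yl, so the large gap seen earlier now appears against a second partner with the same drawn configuration, and among these four compounds the low number stays with the only one carrying piperidin-4-yl.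

From the compounds shown here alone, the piperidin-4-yl group appears here with only one configuration at the stereocentre, so it remains open whether the configuration matters as little with that group as it does with the piperazine compounds. Going by these compounds, it also remains open whether a morpholin-4-yl or dimethylamino group at the end of the chain would give a number like that of the piperazine compounds or one like that of the piperidin-4-yl compound.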